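Trimming Methoxy Groups: From Compound 2 to Compound 4

The source may report more compounds than this note shows. Statements on the series, on what has been measured and on what is new or still open speak of the compounds shown alone.

Measured so far in a functional assay on MCF7 cells (Homo sapiens) for cytotoxicity, read by MTT assay, with a stated time of 72 h; a lower number here means a stronger inhibitor, a higher number a weaker inhibitor:
Compound 1, `COc1ccc(/C=C/C(=O)Nc2cc3c(Nc4ccc(F)c(Cl)c4)ncnc3cc2OC)c(OC)c1`: 36600 nM
Compound 2, `COc1ccc(/C=C/C(=O)Nc2cc3c(Nc4ccc(F)c(Cl)c4)ncnc3cc2O[C@H]2CCOC2)c(OC)c1OC`: 4650 nM
Compound 3, `COc1ccc(OC)c(/C=C/C(=O)Nc2cc3c(Nc4ccc(F)c(Cl)c4)ncnc3cc2OC)c1`: 34300 nM

Among these three, compound 2 stands lowest, and its distance to compound 3 and to compound 1 both lie beyond the usual scatter, so it is the strongest inhibitor of the set. Compound 4, `COc1ccc(/C=C/C(=O)Nc2cc3c(Nc4ccc(F)c(Cl)c4)ncnc3cc2O[C@H]2CCOC2)cc1`, has not been measured yet. It differs from compound 2 in one place: 4-methoxyphenyl in place of 2,3,4-trimethoxyphenyl on a double-bonded chain carbon bound to a double-bonded chain carbon. Among the compounds with values here, only one measured step touches the same part of the molecule, a 1.1-fold lower number from compound 1 to compound 3 (0.03 log units; within the scatter), which moved methoxy groups around the ring and lies within the scatter. Within the data shown here, no measured pair shows what removing two methoxy groups does, and compound 2 differs from compound 1 and compound 3 in two places at once, so those values give no clean step. Because a 1.1-fold lower number from compound 1 to compound 3 (0.03 log units; within the scatter) is flat, shuffling methoxy groups seems to cost little here; taking two of them away is a bigger change, and a moderate rise in the number is expected, a 2.2-fold higher number from compound 2 to compound 4 (0.33 log units; beyond the scatter). Compound 4 is therefore estimated at 10000 nM, with a likely range from 3500 nM to 30000 nM.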

Compound 4, half-maximal inhibitory concentration: 5070 nM
The estimate for compound 4 lay 2.0-fold (0.29 log units) above the measured number; the measured number falls inside the stated range.
By their numbers in this assay, from the lowest: compounds 2 and 4 (each within the scatter of the next); then compounds 3 and 1 (each within the scatter of the next).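

In this assay, replacing 2,3,4-trimethoxyphenyl with 4-methoxyphenyl on a double-bonded chain carbon bound to a double-bonded chain carbon gives a 1.1-fold higher number from compound 2 to compound 4 (0.04 log units; within the scatter). Within the data shown here, the earlier step, a 1.1-fold lower number from compound 1 to compound 3 (0.03 log units; within the scatter), showed only that moving methoxy groups around the ring changed little, whereas this one shows that the aryl group can shrink from 12 heavy atoms to 8, and from 3 hydrogen-bond acceptors to 1, without a change beyond the scatter. Nothing available explains why this change leaves the number so flat.

As far as these compounds go, it remains open whether the last methoxy group matters, and a plain phenyl ring, or a ring carrying an amine or a carboxylic acid in its place, would test how much this part of the molecule tolerates. Also unresolved is what separates compounds 2 and 4 from compounds 1 and 3, as every pair drawn across those two groups differs in more than one place, so no single change can be credited.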